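Extending the chain on the oxygen of compound 3

This account rests on a few compounds, and the source may have more. Where it says the series, first, only, none or still open, it means among the compounds named here.

Compound 3 `CC(C)=CCOc1cc(=O)n(CCCO)c2c1CC(CC=C(C)C)C(C)(C)C2` gives 20.7% in a functional assay on PANC-1 cells (Homo sapiens) for inhibition, read by MTT assay, with a stated time of 24 h, tested at 10 uM (on this read-out lower numbers stand for less inhibition and higher numbers for more inhibition at the one concentration tested (going by the name of the read-out)), the second highest of three numbers: near compound 1 `CC(C)=CCC1Cc2c(O)cc(=O)n(CCCO)c2CC1(C)C` with 25.6%, and clearly above compound 2 `CC(C)=CCC1Cc2c(OCc3ccccc3)cc(=O)n(CCCO)c2CC1(C)C` with -0.3%. Compound 4 `CC(C)=CCC/C(C)=C/COc1cc(=O)n(CCCO)c2c1CC(CC=C(C)C)C(C)(C)C2` differs from compound 3 in one place: 3-methylbut-2-en-1-yl in place of hydrogen on a saturated chain carbon bound to a double-bonded chain carbon. Among the measured compounds shown here, no measured step lengthens that chain, so the nearest guides are a number 4.9 percentage points lower from compound 1 to compound 3 (within the scatter), where the same group first entered on an oxygen on an aromatic ring, and a number 21 percentage points higher from compound 2 to compound 3 (beyond the scatter), while a benzyl group on that oxygen gave a number 25.9 percentage points lower from compound 1 to compound 2 (beyond the scatter). A small drop or no change beyond the scatter is therefore expected, a number 5.7 percentage points lower from compound 3 to compound 4 (within the scatter). Compound 4 is estimated at 15%, between -5% and 35%.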

Compound 4, a percentage reported as inhibition, at one concentration (the size of the read-out at that concentration, not a potency): 10.6%
Beside the measured number, compound 4's estimate is 4.4 percentage points above it; the measured number falls inside the stated range.
By their numbers in this assay, from the lowest: compound 2; then compound 4; then compounds 3 and 1 (each within the scatter of the next).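

Lengthening the group on the oxygen to 3,7-dimethylocta-2,6-dien-1-yl lowers the number in this assay beyond the scatter, both against the shorter chain (a number 10.1 percentage points lower from compound 3 to compound 4 (beyond the scatter)) and against hydrogen on that oxygen (a number 15 percentage points lower from compound 1 to compound 4 (beyond the scatter)), so this position does not accept every added chain equally. The longer chain still reads above benzyl on the same oxygen (a number 10.9 percentage points higher from compound 2 to compound 4 (beyond the scatter)). No measurement shown explains these differences. Still open, as far as these compounds go, is how an amine or a carboxylic acid at the end of this chain, or a small ethyl group on the oxygen, would read.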